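From 1-phenylethyl to butyl on an amine nitrogen

The source may report more compounds than this note shows. Statements on the series, on what has been measured and on what is new or still open speak of the compounds shown alone.

In an ADME assay on L6 cells (Rattus norvegicus) for cytotoxicity (on this read-out lower numbers stand for stronger inhibition and higher numbers for weaker inhibition), compound 1 `COc1cc2c(cc1C(C)OCc1ccccc1)C=CC(C)(C)O2` gives 43900 nM and compound 2 `COc1cc2c(cc1C(C)OC/C=C/c1ccccc1)C=CC(C)(C)O2` gives 64400 nM. Compound 3 `COc1cc2c(cc1C(C)N[C@H](C)c1ccccc1)C=CC(C)(C)O2` gives 15900 nM, the lowest of the three numbers, and its gap to each of the other two lies beyond the scatter.

Compound 4 `CCCCNC(C)c1cc2c(cc1OC)OC(C)(C)C=C2` has not yet been measured and differs from compound 3 in one place: butyl in place of 1-phenylethyl on an amine nitrogen. For the measured compounds named here, no measured step makes this exchange. Going by the values given here, the only step available is a 1.5-fold higher number from compound 1 to compound 2 (0.17 log units; within the scatter), which puts 2-phenylethenyl in place of phenyl on a saturated chain carbon bound to an oxygen. That step stays within the scatter, and it sits on a different linkage, so it offers only weak guidance. A change within the scatter is therefore expected in this assay, leaning slightly upward, with the direction uncertain. The estimated change is a 1.4-fold higher number from compound 3 to compound 4 (0.14 log units; within the scatter). The value expected for compound 4 is 22000 nM, with an estimated range of 9000 nM to 55000 nM.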

Compound 4, half-maximal inhibitory concentration: 52500 nM
For compound 4 the middle estimate is 2.4-fold (0.38 log units) below the measured one; the measured number falls inside the stated range.
By their numbers in this assay, from the lowest: compound 3; then compounds 1, 4 and 2 (each within the scatter of the next).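

In this assay, for the compounds shown here, this is the first measured change on the amine nitrogen, and it is not a neutral one (a 3.3-fold higher number from compound 3 to compound 4 (0.52 log units; beyond the scatter)): the open-chain butyl gives a number clearly above that of 1-phenylethyl, which carries an aromatic ring and a defined stereocentre. The low number of compound 3 therefore depends on the 1-phenylethyl group and not on the amine nitrogen alone, since butylamino in place of benzyloxy leaves the number within the scatter (a 1.2-fold higher number from compound 1 to compound 4 (0.08 log units; within the scatter)). Nothing measured here explains why the group on the nitrogen matters.

From the compounds shown here alone, it remains open whether the aromatic ring, the defined stereocentre or simply the size of the group accounts for the gap. Cyclohexyl, or a longer chain such as octyl, on the same nitrogen would help to separate these possibilities.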